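A Chloro Substituent on the Core of Compound 1

The source may hold more compounds than are shown below. What is called first, only, known or untested is meant among the compounds shown, and "the series" means these compounds.

Compound 1 `O=c1c(-c2cccc([N+](=O)[O-])c2)nc2ccccc2n1Cc1ccccc1` has the lowest number of the three measured compounds in an assay on cells for activation of Cystic fibrosis transmembrane conductance regulator (Homo sapiens), read by fluorescence, with a stated time of 10 min (a lower number here means that less compound is needed, a higher number that more compound is needed for the effect), giving 9 nM. Compound 3 `O=c1c(-c2ccc3nonc3c2)nc2ccccc2n1Cc1ccccc1` lies nearest, at 18 nM, a step of a 2.0-fold higher number from compound 1 to compound 3 (0.30 log units; within the scatter). Compound 2 `O=c1c(-c2ccc(F)c([N+](=O)[O-])c2)nc2ccccc2n1Cc1ccccc1` is furthest, at 690 nM, with a step of a 77-fold higher number from compound 1 to compound 2 (1.88 log units; beyond the scatter). Compound 4 `O=c1c(-c2cccc([N+](=O)[O-])c2)nc2cc(Cl)ccc2n1Cc1ccccc1` is not yet measured; it differs from compound 1 by chloro in place of hydrogen on an aromatic carbon. Neither measured step bears directly on this change: both alter the pendant aryl group, whereas the chloro of compound 4 sits on the shared core, which is unchanged in compounds 2 and 3. The step from compound 1 to compound 2 shows that a single-atom change on the pendant ring can be large, but no comparable measurement exists for the core. A step of a 1.3-fold higher number from compound 1 to compound 4 (0.12 log units; within the scatter) is therefore expected, probably within the scatter. Compound 4 is estimated at 12 nM, with a range from 4 nM to 40 nM.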

Compound 4, half-maximal effective concentration: 70 nM
Beside the measured number, compound 4's estimate is 5.8-fold (0.77 log units) below it; measured number outside the range, above it.
By their numbers in this assay, from the lowest: compounds 1 and 3 (each within the scatter of the next); then compound 4; then compound 2.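

In this assay, among the compounds shown here, the core of compound 1 proves sensitive to substitution, which the earlier compounds could not show because they changed only the pendant aryl group: chloro in place of hydrogen gives a 7.8-fold higher number from compound 1 to compound 4 (0.89 log units; beyond the scatter), a step beyond the scatter. The change is a single added chlorine on the six-membered aromatic ring of carbon only, meta to a fused ring and para to a fused ring, and it still moves the number appreciably. No measurement shown accounts for this shift.

The compounds shown leave open whether fluoro, methyl, methoxy or an amine at this same place would give a similar step, or whether the step is particular to chloro. They also leave open whether chloro on the other aromatic carbons of the shared core, or on the core of compound 3, would have a comparable effect.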